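This account rests on a few compounds, and the source may have more. Where it says the series, first, only, none or still open, it means among the compounds named here.

Compound 1 `O=C(NCCCCc1ccccc1)n1c(=O)oc2ccc(-c3ccc(F)cc3)cc21` and compound 2 `O=C(c1ccccc1)c1ccc2c(c1)oc(=O)n2C(=O)NCCCCc1ccccc1` are the two compounds with measurements so far, and they share a common core. In an assay on HEK293 cells for inhibition of acid ceramidase (Homo sapiens), with a stated time of 10 min (on this read-out lower numbers stand for stronger inhibition and higher numbers for weaker inhibition), compound 1 gives 56 nM, while compound 2 gives 29 nM. Of these two numbers compound 1 has the higher one, but its gap to compound 2 lies within the usual scatter of repeated measurements, so the two compounds cannot be told apart on these data. Compound 3 `O=C(NCCCCc1ccccc1)n1c(=O)oc2ccc(Cl)cc21` has not yet been measured. It differs from compound 1 by a single change: chloro in place of 4-fluorophenyl on an aromatic carbon. For the measured compounds named here, no step between measured compounds shows what such a change does here, so the expectation rests on the structural change alone; the estimate is a moderate weakening of inhibition, a step of a 2.5-fold higher number from compound 1 to compound 3 (0.40 log units; beyond the scatter), somewhat beyond the scatter. The expected value for compound 3 in this assay is 140 nM, with a range from 40 nM to 500 nM.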

Compound 3, half-maximal inhibitory concentration: 15 nM
Compound 3: the middle estimate sits 9.3-fold (0.97 log units) above what was measured; the whole stated range lies above it.
By their numbers in this assay, from the lowest: compounds 3, 2 and 1 (each within the scatter of the next, the first and the last beyond it).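

In this assay, putting chloro in place of 4-fluorophenyl on this aromatic carbon gives a 3.7-fold lower number from compound 1 to compound 3 (0.57 log units; beyond the scatter). For the compounds shown here, this is the first comparison here of compounds differing in one place, and it shows that the six-membered aromatic ring of the 4-fluorophenyl group is not needed at this position for strong inhibition: a single chlorine atom gives the lower number despite replacing seven heavy atoms. Nothing available explains why the smaller group gives the lower number.

On these data alone, with only these two groups compared at this position, it stays open whether the lower number depends on chlorine itself or would come with any small group. As far as these compounds go, how a hydrogen, a fluoro, a methyl or an amine on this same carbon would compare also remains unknown.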